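Methylpiperazine in Place of Benzylamine on a Dienamide

The source may report more compounds than this note shows. Statements on the series, on what has been measured and on what is new or still open speak of the compounds shown alone.

compound 1 `COc1ccc(C[C@@H](O)/C=C/C=C/C(=O)NCc2ccccc2)cc1OC` gives 33600 nM
compound 2 `CCNC(=O)/C=C/C=C/[C@H](O)Cc1ccc(OC)c(OC)c1` gives 12900 nM
compound 3 `COc1ccc(C[C@@H](O)/C=C/C=C/C(=O)N2CCN(c3ncccn3)CC2)cc1OC` gives 14700 nM

The three compounds share one core and differ only at the amide end. In a functional assay on MCF7 cells (Homo sapiens) for antiproliferative activity, read by sulforhodamine B assay, with a stated time of 48 h (a lower number here means a stronger inhibitor, a higher number a weaker inhibitor), compound 1 stands highest of the three numbers; compound 3 lies nearest to it, and compound 2 lies furthest from it. Among the compounds with values here, the one step that can be read directly is a 2.6-fold lower number from compound 1 to compound 2 (0.42 log units; beyond the scatter), which shows that losing the phenyl from the amide substituent lowers the number modestly.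

The unmeasured compound 4 `COc1ccc(C[C@@H](O)/C=C/C=C/C(=O)N2CCN(C)CC2)cc1OC` is reached from compound 1 by the change (4-methylpiperazin-1-yl in place of benzylamino on a carbonyl carbon). This also removes the phenyl, so the step from compound 1 to compound 2 is the best guide, while compound 3 shows what a piperazine amide on this core gives. Both point the same way: a lower number than compound 1, by a modest amount rather than a large one. Compound 4 is therefore expected at 15000 nM, within 6000 nM to 40000 nM, a step of a 2.2-fold lower number from compound 1 to compound 4 (0.35 log units; beyond the scatter) that is expected to lie just beyond the scatter.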

Compound 4, half-maximal inhibitory concentration: 17100 nM
Estimate against measurement, compound 4: 1.1-fold (0.06 log units) below; low and high end bracket the measured number.
By their numbers in this assay, from the lowest: compounds 2, 3, 4 and 1 (each within the scatter of the next, the first and the last beyond it).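

In this assay, 4-methylpiperazin-1-yl in place of benzylamino on the carbonyl carbon gives a 2.0-fold lower number from compound 1 to compound 4 (0.29 log units; within the scatter), so this exchange, which removes both the phenyl ring and the amide hydrogen, cannot be told apart from no change, whereas the step to the ethyl amide, a 2.6-fold lower number from compound 1 to compound 2 (0.42 log units; beyond the scatter), was beyond the scatter. The substituent on the piperazine nitrogen also makes no readable difference here: methyl in place of pyrimidin-2-yl gives a 1.2-fold higher number from compound 3 to compound 4 (0.07 log units; within the scatter), so the pyrimidin-2-yl ring shows no measurable contribution in this pair. Loss of the amide hydrogen likewise leaves no readable mark, since 4-methylpiperazin-1-yl in place of ethylamino gives a 1.3-fold higher number from compound 2 to compound 4 (0.12 log units; within the scatter), and no supporting data bear on why these amide groups give such similar numbers.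

As far as these compounds go, it remains open whether any group on this carbonyl carbon can move the number far from this narrow band, for example morpholin-4-yl, a piperazine with a free ring amine, or a longer chain on the amide nitrogen. The compounds shown also leave open what a carboxylic acid at this position would give.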